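Series notes: hydroxy removal from compound 3

The compounds below may be only part of what the source reports. "The series", "measured", "known", "first", "only" and "open" are said of these compounds alone.

Values in a functional assay on DU-145 cells (Homo sapiens) for inhibition, read by trypan blue exclusion, with a stated time of 96 h; a lower number here means a stronger inhibitor of growth, a higher number a weaker inhibitor of growth:
- compound 1 `O=C(/C(=C\c1ccc(Br)cc1)SCc1ccc(Cl)cc1)c1ccc(Br)cc1`: 1000 nM
- compound 2 `O=C(/C(=C\c1ccc(O)cc1)SCc1ccc(Cl)cc1)c1ccc(Br)cc1`: 10000 nM
- compound 3 `COc1ccc(/C=C(/SCc2ccc(Cl)cc2)C(=O)c2ccc(Br)cc2)cc1O`: 1000 nM

Level with compound 1, compound 3 stands at 1000 nM, together the lowest of the three numbers. Compound 4 `COc1ccc(/C=C(/SCc2ccc(Cl)cc2)C(=O)c2ccc(Br)cc2)cc1` carries hydrogen in place of hydroxy on an aromatic carbon, giving 4-methoxyphenyl instead of 3-hydroxy-4-methoxyphenyl. Among the compounds with values here, no measured step makes this exact change. The closest evidence is a 10-fold higher number from compound 1 to compound 2 (1.00 log units; beyond the scatter), a 10-fold lower number from compound 2 to compound 3 (1.00 log units; beyond the scatter) and no change at the digits printed from compound 1 to compound 3 (within the scatter). Compounds 2 and 3 both carry a hydroxy yet differ, so the presence of a hydroxy alone does not fix the number here. The expected step, with no firm direction, is no change at the digits printed from compound 3 to compound 4 (within the scatter). For compound 4 the estimate is 1000 nM, with an expected range of 300 nM to 5000 nM.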

Compound 4, concentration for 50% growth inhibition: 10000 nM
For compound 4 the middle estimate is 10-fold (1.00 log units) below the measured one; measured number outside the range, above it.
By their numbers in this assay, from the lowest: compounds 1 and 3 (each within the scatter of the next); then compounds 2 and 4 (each within the scatter of the next).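

In this assay, within the data shown here, the hydroxy ortho to a methoxy group matters for the first time in a direct pair: a 10-fold higher number from compound 3 to compound 4 (1.00 log units; beyond the scatter). Capping the oxygen of the lone phenol changes nothing, no change at the digits printed from compound 2 to compound 4 (within the scatter), so 4-methoxyphenyl gives no gain over 4-hydroxyphenyl. The 4-bromophenyl group remains ahead of 4-methoxyphenyl, a 10-fold higher number from compound 1 to compound 4 (1.00 log units; beyond the scatter), and the added hydroxy of 3-hydroxy-4-methoxyphenyl is what brings compound 3 level with compound 1.

On these data alone, whether an amine or a carboxylic acid could stand in place of this hydroxy remains open. No evidence on the compounds accounts for the step.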